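Adding dimethylsulfamoyl to a compound at the assay limit

The source may report more compounds than this note shows. Statements on the series, on what has been measured and on what is new or still open speak of the compounds shown alone.

In an ADME assay on microsomes from liver (Mus musculus) for metabolic stability, read by LC-MS, with NADPH named in the record, with a stated time of 60 min, tested at 1 uM, in the absence of a further agent (a higher number here means that more of the compound is left, a lower number that less of the compound is left), compound 1 `CC(=O)N[C@@H]1CCN(c2cc(C)nn3c(-c4ccccc4)c(C)nc23)C1` gives > 95% as a limit of the assay, not a number. Compound 2 `COc1ccc(-c2c(C)nc3c(N4CC[C@@H](NC(C)=O)C4)cc(C)nn23)cc1F` gives > 95% as a limit too. Among the measured compounds shown here, the one measured step (a step that the two limits leave unreadable from compound 1 to compound 2) puts 3-fluoro-4-methoxyphenyl in place of phenyl on an aromatic carbon, and with both compounds at the same limit (the limit of > 95% in this assay, at which 2 of the 2 values shown sit) it offers no size to carry over. Compound 3 `CC(=O)N[C@@H]1CCN(c2cc(C)nn3c(-c4cccc(S(=O)(=O)N(C)C)c4)c(C)nc23)C1` carries dimethylsulfamoyl in place of hydrogen on an aromatic carbon, meta to a large group (dimethylsulfamoyl in place of hydrogen on an aromatic carbon). A small fall is therefore expected (a number at least 5 percentage points lower from compound 1 to compound 3 (that floor lies within the scatter)). Compound 3 is estimated at 90% (range 72% to 99%).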

Compound 3, percent of the compound remaining: > 95%
Compound 3: only a limit was reported (the forecaster's own chance of this, stated with the estimate: 40%); at least 5 percentage points between middle value and limit.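

No step can be read from compound 1 to compound 3, because both sit at the same limit, which is not a number: the limit of > 95% in this assay, at which 3 of the 3 values shown sit. From the compounds shown here alone, whether dimethylsulfamoyl changes the result in this assay at all stays open.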